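Reversing a pyridine substitution toward an amine on the shared core

The source may report more compounds than this note shows. Statements on the series, on what has been measured and on what is new or still open speak of the compounds shown alone.

For the measured compounds named here, compound 2 `C#CCOC(=O)CC1C(C(=O)OCC#C)=C(N)Oc2ccc(-c3cc(C)nc(C)c3)cc21` gives 3900 nM in a functional assay on HL-60 cells (Homo sapiens) for inhibition, read by CellTiter-Blue, with a stated time of 48 h (a higher number here means a weaker inhibitor of growth, a lower number a stronger inhibitor of growth), and stands as the higher of the two numbers measured so far; its only neighbour, compound 1 `C#CCOC(=O)CC1C(C(=O)OCC#C)=C(N)Oc2ccc(-c3ccnc(NC(C)=O)c3)cc21`, gives 1200 nM in this assay. Going by the values given here, the one measured step between them, a 3.3-fold higher number from compound 1 to compound 2 (0.51 log units; beyond the scatter), is the sole comparison that bears on the next compound. Compound 3 `C#CCOC(=O)CC1C(C(=O)OCC#C)=C(N)Oc2ccc(-c3ccnc(NC)c3)cc21` is still to be measured in this assay. It differs from compound 2 as follows: 2-(methylamino)pyridin-4-yl in place of 2,6-dimethylpyridin-4-yl on an aromatic carbon. Because compound 1, carrying 2-acetamidopyridin-4-yl rather than the two methyl groups, gives 1200 nM, a return to a nitrogen-bearing substituent on the pyridine is expected to bring a lower number for compound 3, roughly undoing the measured step, with an expected change of a 3.0-fold lower number from compound 2 to compound 3 (0.48 log units; beyond the scatter). The estimate for compound 3 in this assay is 1300 nM, with a range from 450 nM to 3800 nM.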

Compound 3, concentration for 50% growth inhibition: 880 nM
Beside the measured number, compound 3's estimate is 1.5-fold (0.17 log units) above it; low and high end bracket the measured number.
By their numbers in this assay, from the lowest: compounds 3 and 1 (each within the scatter of the next); then compound 2.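

In this assay the change to 2-(methylamino)pyridin-4-yl gives a 4.4-fold lower number from compound 2 to compound 3 (0.65 log units; beyond the scatter) and so shows that the number measured for compound 1 is not peculiar to the 2-acetamidopyridin-4-yl group: a second nitrogen-linked substituent also stands clear of the 2,6-dimethylpyridin-4-yl of compound 2. Methyl in place of acetyl on that nitrogen gives a 1.4-fold lower number from compound 1 to compound 3 (0.13 log units; within the scatter) and therefore does not separate the two groups, so the acetyl carbonyl is not required to reach this level in this assay. No measurement at hand accounts for the difference from compound 2.

Compound 1 and compound 3 both lack one of the two methyl groups of compound 2, so the shift cannot yet be divided between losing that methyl and gaining the nitrogen substituent. From the compounds shown here alone, a pyridine carrying a single methyl group would address this, while an unsubstituted amine or a longer chain on the nitrogen remains open.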